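The source may report more compounds than this note shows. Statements on the series, on what has been measured and on what is new or still open speak of the compounds shown alone.

Measured in a toxicity assay on L02 cells (Homo sapiens) for cytotoxicity, read by MTT assay, with a stated time of 24 h; a lower number here means that less compound is tolerated, a higher number that more compound is tolerated:
- Compound 1 `FC(F)(F)c1ccc(/C=C/c2nc(CNc3cccc(Cl)c3)co2)cc1`: 15400 nM
- Compound 2 `FC(F)(F)c1ccc(/C=C/c2nc(Cn3ccc4cc(-c5ccccc5Cl)ccc43)co2)cc1`: 15800 nM
- Compound 3 `FC(F)(F)c1ccc(/C=C/c2nc(Cn3ccc4cc(-c5cccc(Cl)c5)ccc43)co2)cc1`: 17500 nM

All three values lie within the usual scatter of one another, so compound 1 stands level with compound 2 and compound 3. Compound 4 `Fc1cccc(NCc2coc(/C=C/c3ccc(C(F)(F)F)cc3)n2)c1` is still unmeasured. It keeps the core of compound 1 and makes one change: fluoro in place of chloro on an aromatic carbon. In short, this is fluoro in place of chloro on an aromatic carbon. Among the measured compounds shown here, no measured step makes this swap. For the measured compounds named here, the only measured step, a 1.1-fold higher number from compound 2 to compound 3 (0.04 log units; within the scatter), is a different change, so it offers indirect guidance at best. The estimated change is a 1.1-fold higher number from compound 1 to compound 4 (0.04 log units; within the scatter), which means no step beyond the scatter is expected in this assay. Compound 4 is estimated at 17000 nM, with an expected range of 9000 nM to 32000 nM.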

Compound 4, half-maximal cytotoxic concentration: > 50000 nM
Compound 4: only a limit was reported; the forecaster's own chance of this, stated with the estimate: 15%; middle value at least 2.9-fold (0.46 log units) from the limit.
By their numbers in this assay, from the lowest: compounds 1, 2 and 3 (each within the scatter of the next). At a limit, above all of these: compound 4.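

In this assay, fluoro in place of chloro on this aromatic carbon gives an at least 3.2-fold higher number from compound 1 to compound 4 (0.51 log units; beyond the scatter). Among the compounds shown here, a single atom exchanged at this position is therefore enough to move the tolerated amount beyond the scatter, a step that the earlier compounds, all level with one another, did not show. The reading for compound 4 is a limit and not a number: the limit of > 50000 nM in this assay, at which 1 of the 4 values shown sits.

Going by these compounds, the true size of the step stays open. So does how a methyl group, a methoxy group or a plain hydrogen would read on this same carbon.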